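Series notes: chloro in place of methoxy on the sulfonyl aryl

The source may report more compounds than this note shows. Statements on the series, on what has been measured and on what is new or still open speak of the compounds shown alone.

Compound 3 `CCOC(=O)c1oc2ccc(N(Cc3ccccc3)S(=O)(=O)c3ccc(OC)cc3)cc2c1C` carries a 4-methoxyphenyl group on the sulfonyl sulfur together with a benzyl group on the nitrogen of the shared core. In a functional assay on HCT-116 cells (Homo sapiens) for inhibition, read by MTT assay, with a stated time of 72 h (a lower number here means a stronger inhibitor, a higher number a weaker inhibitor), compound 3 returns only a limit, > 40000 nM. Compound 2 `CCOC(=O)c1oc2ccc(N(Cc3ccccc3)S(=O)(=O)c3ccccc3Br)cc2c1C`, its 2-bromophenyl counterpart, likewise returns only a limit in this assay, > 40000 nM. The step that the two limits leave unreadable from compound 2 to compound 3 therefore cannot be sized. Among the compounds with values here, the one numbered value in the set belongs to compound 1 `CCOC(=O)c1oc2ccc(NS(=O)(=O)c3ccc(Cl)cc3)cc2c1C`, which lacks the benzyl group and carries a 4-chlorophenyl group on the sulfonyl sulfur; in this assay compound 1 gives 24300 nM.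

Compound 4 `CCOC(=O)c1oc2ccc(N(Cc3ccccc3)S(=O)(=O)c3ccc(Cl)cc3)cc2c1C` differs from compound 3 by chloro in place of methoxy on an aromatic carbon. Within the data shown here, no measured step in the set reports this exchange with readable size, since both sulfonyl-aryl variants sit at the limit (the limit of > 40000 nM in this assay, at which 2 of the 3 values shown sit). Among the measured compounds shown here, compound 1 shows that a 4-chlorophenyl group can be paired with weak but numbered inhibition, yet the benzyl group separates it from compound 4 and no step for that pair is available. The expected outcome for compound 4 is therefore weak inhibition near the limit, with the step that the limit leaves unreadable from compound 3 to compound 4 estimated as no more than scatter. Compound 4 is estimated at 45000 nM, within 20000 nM to 110000 nM.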

Compound 4, half-maximal inhibitory concentration: 4860 nM
The estimate for compound 4 lay 9.3-fold (0.97 log units) above the measured number; measured number below the stated range.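

In this assay the sulfonyl aryl group does matter once benzyl sits on the nitrogen: chloro in place of methoxy, para to a large group, gives an at least 8.2-fold lower number from compound 3 to compound 4 (0.91 log units; beyond the scatter), and 4-chlorophenyl in place of 2-bromophenyl gives an at least 8.2-fold lower number from compound 2 to compound 4 (0.91 log units; beyond the scatter). With 4-chlorophenyl held fixed, the benzyl group can now be sized too, since benzyl in place of hydrogen on the sulfonamide nitrogen gives a 5.0-fold lower number from compound 1 to compound 4 (0.70 log units; beyond the scatter). Benzyl therefore does not by itself place a compound at the limit, and among the benzyl compounds shown only compound 4 gives a number, while compound 2 and compound 3 remain limits: the limit of > 40000 nM in this assay, at which 2 of the 4 values shown sit.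

Going by these compounds, the step between compound 2 and compound 3 cannot be read, so the order of 2-bromophenyl and 4-methoxyphenyl stays open. Also open, on these data alone, is whether the gain is specific to chloro or would carry over to fluoro, a nitrile or an amine at the same place on the sulfonyl aryl ring, and whether it would survive a longer chain in place of benzyl or a carboxylic acid in place of the ethyl ester.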